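Compound 3 to compound 4: fluoro in place of chloro

A few compounds are considered here, and "the series" means these few. Any claim that something is new, unique, unknown or untested is made for them only; others in the source may bear on it.

In an ADME assay on L132 cells (Homo sapiens) for cytotoxicity, read by MTT assay, with a stated time of 72 h (on this read-out higher numbers stand for weaker inhibition and lower numbers for stronger inhibition), compound 3 (`COc1ccc(C2=C(c3cc(OC)c(OC)c(OC)c3)C(=O)C(O)C2)cc1Cl`) gives < 1 ug/mL as a limit and not a number. Compound 2 (`COc1ccc(C2=C(c3cc(OC)c(OC)c(OC)c3)C(=O)C(OC(C)=O)C2)cc1F`) gives < 1 ug/mL as a limit as well. Compound 1 (`C=CCOc1cc(C2=C(c3cc(OC)c(OC)c(OC)c3)C(=O)C(O)C2)ccc1OC`) gives > 100 ug/mL as a limit too. Compound 4 (`COc1ccc(C2=C(c3cc(OC)c(OC)c(OC)c3)C(=O)C(O)C2)cc1F`) changes 3-chloro-4-methoxyphenyl to 3-fluoro-4-methoxyphenyl (fluoro in place of chloro on an aromatic carbon), with fluoro in place of chloro on an aromatic carbon. Among the measured compounds shown here, the only measured step (an at least 100-fold lower number from compound 1 to compound 3 (2.00 log units; beyond the scatter)) is large, but there allyloxy leaves, not chloro, so it bears only indirectly. Compound 2 already carries 3-fluoro-4-methoxyphenyl, and its value sits at the same limit as that of compound 3. No step beyond the scatter is expected in this assay (a step that the limit leaves unreadable from compound 3 to compound 4) in either direction. Compound 4 is expected at 0.6 ug/mL (estimated range 0.1 ug/mL to 2 ug/mL).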

Compound 4, half-maximal inhibitory concentration: < 1 ug/mL
Compound 4 was reported as a limit (the forecaster's own chance of this, stated with the estimate: 70%); the middle value lies beyond the limit too.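

In this assay there is an at least 100-fold lower number from compound 1 to compound 4 (2.00 log units; beyond the scatter), where allyloxy gives way to fluoro, so the large step seen with chloro also appears with this second halogen. The steps from compound 3 to compound 4 and from compound 2 to compound 4 cannot be read, because both ends of each sit at the same limit: the limit of < 1 ug/mL in this assay, at which 3 of the 4 values shown sit.

Going by these compounds, how chloro, fluoro and the acetyl on oxygen rank beneath that limit stays open. So does what an amine or a nitrile would give at this position.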